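This account rests on a few compounds, and the source may have more. Where it says the series, first, only, none or still open, it means among the compounds named here.

Measured compounds:
Compound 1, `CCS(=O)(=O)Nc1ccc(NC(=O)c2ccc(Cl)cc2)cc1Cl`, gives > 250000 nM in an ADME assay on RAW264.7 cells (Mus musculus) for cytotoxicity, read by MTT assay, with a stated time of 48 h (on this read-out lower numbers stand for stronger inhibition and higher numbers for weaker inhibition), and this value is a limit of the assay rather than a number.
Compound 2, `CCS(=O)(=O)Nc1ccc(NC(=O)c2ccc(C#N)cc2)cc1Cl`, gives 226000 nM.
Compound 3, `CCS(=O)(=O)Nc1ccc(NC(=O)c2ccc(Cl)cc2)cc1F`, gives 152000 nM.

All three share one core and differ at two points. From compound 1 to compound 2 the change is cyano in place of chloro on an aromatic carbon, and it brings an at least 1.1-fold lower number from compound 1 to compound 2 (0.04 log units; that floor lies within the scatter); this step can only be stated as a floor because of the limit of > 250000 nM in this assay, at which 1 of the 3 values shown sits. From compound 1 to compound 3 the change is fluoro in place of chloro on an aromatic carbon, and it brings an at least 1.6-fold lower number from compound 1 to compound 3 (0.21 log units; that floor lies within the scatter). Among the two numbers recorded, compound 3 stands closest to compound 2, and the gap between them lies within the scatter, so no order between them can be claimed.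

Compound 4, `CCS(=O)(=O)Nc1ccc(NC(=O)c2ccc(C#N)cc2)cc1F`, has not yet been measured in this assay. It differs from compound 3 by cyano in place of chloro on an aromatic carbon, the same change as that made from compound 1 to compound 2, here set on the core of compound 3 rather than that of compound 1.

The expectation for compound 4 rests on the step of an at least 1.1-fold lower number from compound 1 to compound 2 (0.04 log units; that floor lies within the scatter), which lies within the usual scatter, so compound 4 is expected to land close to compound 3 with a step of a 1.2-fold lower number from compound 3 to compound 4 (0.07 log units; within the scatter). For compound 4 the estimated value is 130000 nM, expected to fall between 60000 nM and 250000 nM.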

Compound 4, half-maximal inhibitory concentration: 107000 nM
Estimate against measurement, compound 4: 1.2-fold (0.08 log units) above; low and high end bracket the measured number.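

In this assay, for the compounds shown here, cyano in place of chloro on the fluoro-bearing core brings a 1.4-fold lower number from compound 3 to compound 4 (0.15 log units; within the scatter), while fluoro in place of chloro on the cyano-bearing core brings a 2.1-fold lower number from compound 2 to compound 4 (0.32 log units; beyond the scatter), and only this second step clears the scatter, modestly. Set beside its earlier step, the cyano change can be read only this far: the same change on two cores in this assay, an at least 1.1-fold lower number (0.04 log units; that floor lies within the scatter) from compound 1 to compound 2 and a 1.4-fold lower number (0.15 log units; within the scatter) from compound 3 to compound 4; the limit leaves it open whether they differ. The fluoro change gives no firmer answer, so these compounds show neither that the size of a change carries over from one core to the other nor that it shifts with the core: the same change on two cores in this assay, an at least 1.6-fold lower number (0.21 log units; that floor lies within the scatter) from compound 1 to compound 3 and a 2.1-fold lower number (0.32 log units; beyond the scatter) from compound 2 to compound 4; the limit leaves it open whether they differ.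

The compounds shown leave open how the number would respond to other groups on the aromatic carbon that carries chloro or cyano, such as an amine or a carboxylic acid, or to a longer chain in place of the ethyl group of the shared core. Also open, as far as these compounds go, is the actual number for compound 1, whose > 250000 nM is a limit of the assay and not a number.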